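Methylsulfanyl in place of trifluoromethoxy: working notes

This account rests on a few compounds, and the source may have more. Where it says the series, first, only, none or still open, it means among the compounds named here.

In a functional assay on HCT-116 cells (Homo sapiens) for antiproliferative activity, read by MTT assay, with a stated time of 72 h (on this read-out lower numbers stand for stronger inhibition and higher numbers for weaker inhibition), compound 1 `O=C(CCc1cccc2c1B(O)OC2)Nc1cccc(Br)c1` gives 1400 nM, compound 2 `O=C(CCc1cccc2c1B(O)OC2)Nc1cccc(-c2ccc(Cl)cc2)c1` gives 380 nM and compound 3 `O=C(CCc1cccc2c1B(O)OC2)Nc1cccc(-c2ccc(OC(F)(F)F)cc2)c1` gives 730 nM. Compound 3 lies within the scatter of both other compounds. Compound 4 `CSc1ccc(-c2cccc(NC(=O)CCc3cccc4c3B(O)OC4)c2)cc1` brings methylsulfanyl in place of trifluoromethoxy on an aromatic carbon, para to a large group. For the measured compounds named here, two measured steps bear on this change. The first, a 3.7-fold lower number from compound 1 to compound 2 (0.57 log units; beyond the scatter), installs the 4-chlorophenyl in place of bromo. The second, a 1.9-fold higher number from compound 2 to compound 3 (0.28 log units; within the scatter), exchanges the same substituent and stays within the scatter, so no step beyond the scatter is expected in this assay. The estimated step is a 1.5-fold lower number from compound 3 to compound 4 (0.16 log units; within the scatter). For compound 4 the estimate is 500 nM, with an expected range of 200 nM to 1300 nM.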

Compound 4, half-maximal inhibitory concentration: 180 nM
Beside the measured number, compound 4's estimate is 2.8-fold (0.44 log units) above it; measured number outside the range, below it.
By their numbers in this assay, from the lowest: compound 4; then compounds 2, 3 and 1 (each within the scatter of the next, the first and the last beyond it).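

At this place, on an aromatic carbon para to a large group, methylsulfanyl in place of trifluoromethoxy gives a step beyond the scatter in this assay (a 4.1-fold lower number from compound 3 to compound 4 (0.61 log units; beyond the scatter)), whereas the earlier exchange of chloro for trifluoromethoxy stayed within it. Methylsulfanyl also separates from chloro (a 2.1-fold lower number from compound 2 to compound 4 (0.32 log units; beyond the scatter)), which makes compound 4 the strongest of the set, and the whole 4-(methylsulfanyl)phenyl in place of bromo gives the largest step (a 7.8-fold lower number from compound 1 to compound 4 (0.89 log units; beyond the scatter)). No measurement at hand explains this result.

Going by these compounds, how a methoxy, an amine or a longer thioether chain at this place would compare remains open.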